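This account rests on a few compounds, and the source may have more. Where it says the series, first, only, none or still open, it means among the compounds named here.

Measured in a functional assay for inhibition, with Homo sapiens as the target; on this read-out higher numbers stand for weaker inhibition and lower numbers for stronger inhibition:
- compound 1 `COc1ccc2c(OC(C)C)c(C(=O)Nc3nn[nH]n3)sc2c1`: 37000 nM
- compound 2 `CC(C)Oc1c(C(=O)Nc2nn[nH]n2)sc2ccccc12`: > 100000 nM
- compound 3 `COc1cc2sc(C(=O)Nc3nn[nH]n3)c(OC(C)C)c2cc1OC`: 17700 nM

The entry for compound 2, > 100000 nM, is a limit of the assay and not a number. Of the two true numbers, compound 3 has the lower at 17700 nM, and compound 1 has the higher at 37000 nM.

Compound 4 `COc1ccc2c(OC(C)C)c(C(=O)Nc3nn[nH]n3)sc2c1Cl` is still unmeasured. It differs from compound 1 by chloro in place of hydrogen on an aromatic carbon, ortho to a methoxy group (chloro in place of hydrogen on an aromatic carbon).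

For the measured compounds named here, no measured step involves chloro, so the closest guides are the two methoxy steps. Removing a methoxy gives an at least 2.7-fold higher number from compound 1 to compound 2 (0.43 log units; beyond the scatter), and adding a second gives a 2.1-fold lower number from compound 1 to compound 3 (0.32 log units; beyond the scatter). In these three compounds, more methoxy groups go with a lower number, and none of the three goes against this. By analogy, a modest move towards a lower number is expected in this assay, though with little certainty.

The expected step is a 1.9-fold lower number from compound 1 to compound 4 (0.27 log units; within the scatter).

Compound 4 is estimated at 20000 nM, with an expected range of 6000 nM to 60000 nM.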

Compound 4, half-maximal inhibitory concentration: > 100000 nM
Compound 4: only a limit was reported; the forecaster's own chance of this, stated with the estimate: 10%; at least 5.0-fold (0.69 log units) between middle value and limit.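

In this assay, chloro in place of hydrogen on an aromatic carbon, ortho to a methoxy group, gives an at least 2.7-fold higher number from compound 1 to compound 4 (0.43 log units; beyond the scatter). Compound 4 carries a limit and not a number, so this step gives only a minimum size: the limit of > 100000 nM in this assay, at which 2 of the 4 values shown sit. Of the two single additions to compound 1, methoxy in compound 3 goes with a lower number and chloro at this new position in compound 4 with a higher one, so among these compounds an added group on the aromatic ring does not by itself lower the number.

On these data alone, whether the rise belongs to chloro itself or to any group at this position stays open, as fluoro, methyl or an amine here would be needed to separate the two. As far as these compounds go, whether chloro at another aromatic carbon of the core would behave the same also stays open.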